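Pyridinyl for Fluorophenyl on the Amide Side Chain

A few compounds are considered here, and "the series" means these few. Any claim that something is new, unique, unknown or untested is made for them only; others in the source may bear on it.

Of the compounds shown here, three with a shared core have been measured in a functional assay on cells (Homo sapiens) for cytotoxicity, read by MTT assay, with a stated time of 48 h; a higher number here means a weaker inhibitor, a lower number a stronger inhibitor. Compound 1 `COc1ccc(CNC(=O)CC2c3ccccc3N=C(N(C)CCCCCN(C)C)N2c2ccc(-c3ccccc3)cc2)cc1` gives 2520 nM. Compound 2 `CN(C)CCCCN(C)C1=Nc2ccccc2C(CC(=O)NCc2ccccc2)N1c1ccc(-c2ccccc2)cc1` gives 3970 nM. Compound 3 `CN(C)CCN1CCN(C2=Nc3ccccc3C(CC(=O)NCc3ccc(F)cc3)N2c2ccc(-c3ccccc3)cc2)CC1` gives 4000 nM, the highest of the three numbers, though its gap to compound 2 and its gap to compound 1 both lie within the scatter, so the three cannot be placed in any order. For the measured compounds named here, no two of them differ in one place only, so no single step has been measured.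

Compound 4 `CN(C)CCN1CCN(C2=Nc3ccccc3C(CC(=O)NCc3ccncc3)N2c2ccc(-c3ccccc3)cc2)CC1` is the unmeasured partner of compound 3. The change is pyridin-4-yl in place of 4-fluorophenyl on a saturated chain carbon bound to an amide-type nitrogen. Going by the values given here, nothing among the measured compounds isolates a change of this kind, and the three numbers sit close together whatever group stands on that chain carbon. The step of a 1.1-fold higher number from compound 3 to compound 4 (0.05 log units; within the scatter) is therefore expected to stay within the scatter. Compound 4 is estimated at 4500 nM, with a range from 1800 nM to 11000 nM.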

Compound 4, half-maximal inhibitory concentration: > 5000 nM
Compound 4 ended at the assay's limit (the forecaster's own chance of this, stated with the estimate: 5%); at least 1.1-fold (0.04 log units) between middle value and limit.
By their numbers in this assay, from the lowest: compounds 1, 2 and 3 (each within the scatter of the next). At a limit, above all of these: compound 4.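

In this assay compound 4 gives > 5000 nM, which is a limit of the assay and not a number. Pyridin-4-yl in place of 4-fluorophenyl on a saturated chain carbon bound to an amide-type nitrogen is the first single change read in this series, and it gives an at least 1.2-fold higher number from compound 3 to compound 4 (0.09 log units; that floor lies within the scatter). That step has a floor but no measured size, and the floor does not separate the two compounds, with the reading capped by the assay: the limit of > 5000 nM in this assay, at which 1 of the 4 values shown sits.

On these data alone, how far compound 4 really lies from compound 3 stays open, and the step cannot say whether the ring nitrogen matters at this place. Also open, as far as these compounds go, is what a pyridin-3-yl, a pyridin-2-yl or a carboxylic acid would give on the same chain carbon.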